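Chain amine swap on the shared core: compound 3 to 4

A few compounds are considered here, and "the series" means these few. Any claim that something is new, unique, unknown or untested is made for them only; others in the source may bear on it.

Compound 3 `CN(C)CCCOc1c(OCc2ccccc2)cc(O)c2c(=O)cc(-c3ccccc3)oc12` gives 5420 nM in a functional assay on B16 cells (Mus musculus) for cytotoxicity, read by MTT assay, with a stated time of 72 h; on this read-out lower numbers stand for stronger inhibition and higher numbers for weaker inhibition. Among the three measured numbers compound 3 stands second highest, yet both neighbours lie within the scatter of it: compound 1 `COc1c(OCCCCN2CCN(C)CC2)cc(O)c2c(=O)cc(-c3ccc(C)cc3)oc12` gives 5430 nM, and compound 2 `COc1c(OCCCCN2CCN(C)CC2)cc(O)c2c(=O)cc(-c3ccc(F)cc3Br)oc12` gives 3440 nM. Among the measured compounds shown here, the only measured single-point step, a 1.6-fold lower number from compound 1 to compound 2 (0.20 log units; within the scatter), concerns the aryl group on the shared core and does not touch the amine-bearing chain. Compound 4 `CN1CCN(CCCCOc2c(OCc3ccccc3)cc(O)c3c(=O)cc(-c4ccccc4)oc23)CC1` differs from compound 3 by (4-methylpiperazin-1-yl)methyl in place of dimethylamino on a saturated chain carbon, three bonds along the chain from an oxygen on an aromatic ring. For the measured compounds named here, no measured step addresses this change directly; what the data do show is that compound 1 and compound 2, which carry the larger amine, sit within the scatter of compound 3. The step in this assay is therefore expected to be small, with no clear direction beyond the scatter. Compound 4 is expected to give 5000 nM, with a range from 2500 nM to 11000 nM. The expected step is a 1.1-fold lower number from compound 3 to compound 4 (0.04 log units; within the scatter), judged to stay within the scatter.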

Compound 4, half-maximal inhibitory concentration: 2370 nM
Compound 4: the middle estimate sits 2.1-fold (0.32 log units) above what was measured, outside the stated range (below it).
By their numbers in this assay, from the lowest: compounds 4, 2, 3 and 1 (each within the scatter of the next, the first and the last beyond it).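

In this assay, replacing the 3-(dimethylamino)propyl chain with the 4-(4-methylpiperazin-1-yl)butyl chain gives a 2.3-fold lower number from compound 3 to compound 4 (0.36 log units; beyond the scatter) on the shared core, and this is the only step shown that touches the amine-bearing chain. This position therefore responds modestly to the change, whereas the aryl replacement, a 1.6-fold lower number from compound 1 to compound 2 (0.20 log units; within the scatter) on a different core, stays within the scatter. Nothing at hand accounts for the size or direction of the step.

The amine and the chain length change together here, so the step cannot be assigned to either the 4-methylpiperazin-1-yl group or the longer chain. On these data alone, a 4-(dimethylamino)butyl chain or a 3-(4-methylpiperazin-1-yl)propyl chain on the same core would separate the two, and whether a morpholine behaves like the piperazine also remains open.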